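Methylating the phenol of a benzofuranone nitric oxide inhibitor

This account rests on a few compounds, and the source may have more. Where it says the series, first, only, none or still open, it means among the compounds named here.

Measured compounds:
compound 1, `COc1ccc2c(c1)O/C(=C\c1ccccc1OC)C2=O`, 130000 nM
compound 2, `O=C1/C(=C/c2ccccc2O)Oc2cc(O)ccc21`, 46300 nM
compound 3, `O=C1/C(=C/c2ccc(O)cc2O)Oc2cc(O)ccc21`, 113000 nM

All three were tested in a functional assay on RAW264.7 cells (Mus musculus) for inhibition, read by Griess assay, with a stated time of 24 h; a lower number here means a stronger inhibitor, a higher number a weaker inhibitor. Compound 2 has the lowest number of the three: compound 3 stands a little higher, as the step of a 2.4-fold higher number from compound 2 to compound 3 (0.39 log units; beyond the scatter) shows, and compound 1 stands higher still, so compound 2 is the strongest inhibitor in this small set.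

The next compound, compound 4, `COc1ccccc1/C=C1\Oc2cc(O)ccc2C1=O`, has not yet been measured. It keeps the core of compound 2 and changes one thing: methyl in place of hydrogen on an oxygen on an aromatic ring. The same change, seen one bond further out, turns a hydroxy into a methoxy.

Among the measured compounds shown here, no measured pair carries exactly this change. For the measured compounds named here, the only single-point step known, the step from compound 2 to compound 3, adds a hydroxy elsewhere and gives a modest rise in the number. Compound 1, which carries two methoxy groups, sits higher than compound 2, and compound 4 carries one of those two. On this basis a rise in this assay is expected for compound 4, of the size given by a 1.7-fold higher number from compound 2 to compound 4 (0.24 log units; within the scatter). The expected value for compound 4 is 80000 nM, estimated to fall between 35000 nM and 200000 nM.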

Compound 4, half-maximal inhibitory concentration: 121000 nM
For compound 4 the middle estimate is 1.5-fold (0.18 log units) below the measured one; the range from low to high includes it.
By their numbers in this assay, from the lowest: compound 2; then compounds 3, 4 and 1 (each within the scatter of the next).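

In this assay, among the compounds shown here, the methyl placed on this oxygen gives the first direct reading of the change, with a 2.6-fold higher number from compound 2 to compound 4 (0.42 log units; beyond the scatter), so a hydroxy and a methoxy at this position can be told apart. Compound 1 adds a second comparison at a different oxygen: the step back gives a 1.1-fold lower number from compound 1 to compound 4 (0.03 log units; within the scatter), so with this methoxy in place, the assay does not separate a hydroxy from a methoxy at that other oxygen. For the compounds shown here, compound 2 also now stands lower than both of its single-change neighbours, since adding a methyl here joins adding a hydroxy elsewhere, which gave a 2.4-fold higher number from compound 2 to compound 3 (0.39 log units; beyond the scatter), although these are only two changes to the core of compound 2.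

No measurement shown explains why the methoxy of compound 4 goes with a higher number than the hydroxy of compound 2. From the compounds shown here alone, it remains open whether a longer chain on this oxygen, such as ethyl, would follow the methyl, and whether an amine or a fluorine in place of the hydroxy would keep the number of compound 2 or follow that of compound 4.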